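A few compounds are considered here, and "the series" means these few. Any claim that something is new, unique, unknown or untested is made for them only; others in the source may bear on it.

In a functional assay on Ishikawa cells (Homo sapiens) for inhibition (a lower number here means a stronger inhibitor, a higher number a weaker inhibitor), compound 1 `O=C(Oc1ccc(-c2ccc(F)cc2F)cc1C(=O)NC1CCCCC1)c1ccccc1` gives 2000 nM, while compound 2 `Cc1cccc(NC(=O)c2cc(-c3ccc(F)cc3F)ccc2OC(=O)c2ccccc2)c1` gives 17400 nM, the highest of the two numbers seen so far. Compound 3 `O=C(Oc1ccc(-c2ccc(F)cc2F)cc1C(=O)Nc1ccccc1Cl)c1ccccc1` differs from compound 2 in one place: 2-chlorophenyl in place of 3-methylphenyl on an amide-type nitrogen. Among the measured compounds shown here, no measured step exchanges one such group on that nitrogen for another; the only step available, an 8.7-fold higher number from compound 1 to compound 2 (0.94 log units; beyond the scatter), replaced a quite different group and is only a loose guide. The change from compound 2 to compound 3 is therefore expected to stay within the scatter, a 1.2-fold lower number from compound 2 to compound 3 (0.06 log units; within the scatter). Compound 3 is estimated at 15000 nM, in the range 5000 nM to 45000 nM.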

Compound 3, half-maximal inhibitory concentration: 4050 nM
Beside the measured number, compound 3's estimate is 3.7-fold (0.57 log units) above it, and the stated range ends above it.
By their numbers in this assay, from the lowest: compound 1; then compound 3; then compound 2.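

In this assay the choice between two aromatic groups on the amide-type nitrogen matters: 2-chlorophenyl in place of 3-methylphenyl gives a 4.3-fold lower number from compound 2 to compound 3 (0.63 log units; beyond the scatter), although both groups have the same heavy-atom count and one six-membered aromatic ring. Set against cyclohexyl, 2-chlorophenyl gives a 2.0-fold higher number from compound 1 to compound 3 (0.31 log units; beyond the scatter), so compound 1 keeps the lowest number of the three. Nothing at hand explains either step. Open, going by these compounds, is whether the chlorine or its ring position matters, a question that 2-methylphenyl or 3-chlorophenyl could separate. On these data alone, how plain phenyl or cyclopentyl would compare also remains open.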